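Dropping the Chloro Group: From Compound 2 to Compound 3

The compounds below may be only part of what the source reports. "The series", "measured", "known", "first", "only" and "open" are said of these compounds alone.

Of the compounds shown here, two have been tested in a functional assay on the whole organism (strain CD-1) with Mus musculus as the target, in the maximal electroshock model, with a stated time of 0.5 h; a higher number here means that more compound is needed for the effect, a lower number that less compound is needed. Compound 1 `Cc1cccc(N2CCN(C(=O)CN3C(=O)CC(C)(c4ccccc4)C3=O)CC2)c1` carries a methyl group on its outer aromatic ring, and in this assay compound 1 gives 100 mg/kg. Compound 2 `CC1(c2ccccc2)CC(=O)N(CC(=O)N2CCN(c3cccc(Cl)c3)CC2)C1=O` carries a chloro group at that position instead, and in this assay compound 2 gives 300 mg/kg. For the measured compounds named here, the single measured step, a 3.0-fold higher number from compound 1 to compound 2 (0.48 log units; beyond the scatter), is the only comparison available, and it leaves compound 2 with the highest number of the two.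

Compound 3 `CC1(c2ccccc2)CC(=O)N(CC(=O)N2CCN(c3ccccc3)CC2)C1=O` is the unmeasured member of the set. Its structural change from compound 2 is hydrogen in place of chloro on an aromatic carbon. Going by the values given here, no measured step here involves a hydrogen at this position, so the only guide is the step from compound 1 to compound 2, which is of modest size. Because a 3.0-fold higher number from compound 1 to compound 2 (0.48 log units; beyond the scatter) shows that swapping one small group for another at this carbon shifts the number by a modest amount, the expected step to compound 3 is likewise modest, and its direction is uncertain. The estimate for compound 3 in this assay is therefore 150 mg/kg, expected to lie between 50 mg/kg and 300 mg/kg, which corresponds to an expected step of a 2.0-fold lower number from compound 2 to compound 3 (0.30 log units; within the scatter).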

Compound 3, minimum effective dose: 300 mg/kg
Beside the measured number, compound 3's estimate is 2.0-fold (0.30 log units) below it; measured number inside the range.
By their numbers in this assay, from the lowest: compound 1; then compounds 2 and 3 (each within the scatter of the next).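

In this assay, for the compounds shown here, taking the chloro group away gives no change at the digits printed from compound 2 to compound 3 (within the scatter), so the change from 3-chlorophenyl to phenyl leaves no readable mark on the number, something the earlier pair could not show, as it held no compound with hydrogen at this aromatic carbon. The methyl group now stands apart from both of the other groups: alongside the earlier 3.0-fold higher number from compound 1 to compound 2 (0.48 log units; beyond the scatter), there is also a 3.0-fold higher number from compound 1 to compound 3 (0.48 log units; beyond the scatter), so among these three compounds only compound 1, with its methyl group, separates from the rest, while compound 2 and compound 3 cannot be told apart. Nothing measured here accounts for this difference or for the absence of one between chloro and hydrogen.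

As far as these compounds go, whether an ethyl or a methoxy group on this aromatic carbon would read like the methyl group of compound 1 or like the chloro and hydrogen of compound 2 and compound 3 remains open. Also open, from the compounds shown here alone, is how an amine or a carboxylic acid at this carbon would fare in this assay, and whether a number lower than that of compound 1 can be reached here at all.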